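This account rests on a few compounds, and the source may have more. Where it says the series, first, only, none or still open, it means among the compounds named here.

Compound 2, `CCCNC(=S)NS(=O)(=O)c1ccc(-n2nc(C)cc2C)cc1`, is one of two compounds already measured in a functional assay on the whole organism (blood, strain albino) with Mus musculus as the target, with stated times of 6 days and 4 h, at a dose of 0.4 mmol/kg by the oral route; on this read-out higher numbers stand for more inhibition at the one dose given (going by the name of the read-out) and lower numbers for less inhibition. In this assay compound 2 gives < 1%, which is a limit of the assay and not a number. Its closest measured neighbour is compound 1, `CCNC(=O)NS(=O)(=O)c1ccc(-n2nc(C)cc2C)cc1`, which differs from it only on the sulfonamide nitrogen. In this assay compound 1 gives < 1%, again a limit. The step that the two limits leave unreadable from compound 1 to compound 2 therefore cannot be sized, due to the limit of < 1% in this assay, at which 2 of the 2 values shown sit. The compound still to be measured is compound 3, `CCCCNC(=O)NS(=O)(=O)c1ccc(-n2nc(C)cc2C)cc1`. It differs from compound 2 in one place: a group of 7 heavy atoms (5 carbon, 1 nitrogen, 1 oxygen; no ring) in place of a group of 6 heavy atoms (4 carbon, 1 nitrogen, 1 sulfur; no ring), on a sulfonamide nitrogen. Among the compounds with values here, the only measured step touching that same position is the one from compound 1 to compound 2, and its size is not readable, so nothing measured so far shows how large a step to compound 3 might be. The step expected here is a number at least 1 percentage points higher from compound 2 to compound 3 (that floor lies within the scatter), most likely leaving compound 3 at the limit of the assay. Compound 3 is estimated to give 2% in this assay, within an expected range from 0% to 12%.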

Compound 3, a percentage reported as inhibition, in the whole organism at one dose (the size of the read-out at that dose, not a potency): 2%
Compound 3: middle estimate and measured number agree at the digits printed, and the stated range covers the measured number.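

Within the data shown here, compound 3 is the only one of the three compounds that gives a number rather than a limit in this assay, so this position now has a reading that is not a limit. Replacing the sulfur-bearing group on the sulfonamide nitrogen with butylcarbamoyl, which changes both the sulfur-for-oxygen atom and the chain, gives a number at least 1 percentage points higher from compound 2 to compound 3 (that floor lies within the scatter), while the cleaner change that keeps the carbonyl, ethyl in place of hydrogen on a saturated chain carbon, two bonds along the chain from an amide-type nitrogen, gives a number at least 1 percentage points higher from compound 1 to compound 3 (that floor lies within the scatter). Neither step shows a change that can be told from the scatter, and neither can be sized beyond its floor, due to one feature of these data: the limit of < 1% in this assay, at which 2 of the 3 values shown sit.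

The compounds shown do not separate the effect of swapping sulfur for oxygen from the effect of chain length, since no pair here differs in that atom alone. As far as these compounds go, what a longer chain such as hexyl, a cyclohexyl ring or a carboxylic acid at the end of the chain would do at this position also remains open.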